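A few compounds are considered here, and "the series" means these few. Any claim that something is new, unique, unknown or untested is made for them only; others in the source may bear on it.

Measured so far:
compound 1, `O/N=C(/Nc1ccc(F)c(F)c1)c1ccc2occc2c1`: 22700 nM
compound 2, `O/N=C(/Nc1ccc(F)c(Br)c1)c1ccc2occc2c1`: 1600 nM

Both compounds were tested in an assay on isolated protein for inhibition of Indoleamine 2,3-dioxygenase 1 (Homo sapiens), read by spectrophotometry; on this read-out higher numbers stand for weaker inhibition and lower numbers for stronger inhibition. Compound 1 gives 22700 nM, while compound 2 gives 1600 nM. Within the data shown here, the only change between them is a 14-fold lower number from compound 1 to compound 2 (1.15 log units; beyond the scatter), so compound 2 holds the lowest number of the two, and the gap to compound 1 is beyond the scatter.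

Compound 3, `O/N=C(/Nc1ccc(F)c(C(F)(F)F)c1)c1ccc2occc2c1`, has not yet been measured in this assay. It differs from compound 2 in one place: trifluoromethyl in place of bromo on an aromatic carbon. Among the measured compounds shown here, the one measured step, from compound 1 to compound 2, swapped a fluoro group for a bromo group at this same carbon and lowered the number strongly; it shows that the group at this position matters, but it does not directly show how trifluoromethyl compares with bromo. For the measured compounds named here, with no step of that kind to lean on, the expectation for compound 3 is a number near that of compound 2, with a step of a 1.6-fold higher number from compound 2 to compound 3 (0.19 log units; within the scatter) that may well stay within the scatter. The estimate for compound 3 is therefore 2500 nM, with a range from 700 nM to 9000 nM.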

Compound 3, half-maximal inhibitory concentration: 1200 nM
Compound 3: middle estimate off by 2.1-fold (0.32 log units), on the high side, within the range that was stated.
By their numbers in this assay, from the lowest: compounds 3 and 2 (each within the scatter of the next); then compound 1.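

In this assay, bromo and trifluoromethyl at this aromatic carbon cannot be told apart: the exchange gives a 1.3-fold lower number from compound 2 to compound 3 (0.12 log units; within the scatter), so neither group can be ranked above the other. Replacing fluoro with trifluoromethyl gives a 19-fold lower number from compound 1 to compound 3 (1.28 log units; beyond the scatter), a large change that stands alongside a 14-fold lower number from compound 1 to compound 2 (1.15 log units; beyond the scatter), so two different groups, one with 1 heavy atom and one with 4 heavy atoms, both give far stronger inhibition here than fluoro does. Nothing available explains why fluoro stands apart from these two groups.

The compounds shown cover only fluoro, bromo and trifluoromethyl at this carbon, so it remains open how a plain hydrogen, a methyl group, a methoxy group, an amine or a carboxylic acid would compare there. As far as these compounds go, it is also open whether the close match between bromo and trifluoromethyl would persist if the neighbouring ortho fluoro group were replaced by another group, such as chloro, or if the shared core were changed.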